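A Fluorine Step Repeated on a Weaker Core

A few compounds are considered here, and "the series" means these few. Any claim that something is new, unique, unknown or untested is made for them only; others in the source may bear on it.

Compound 1 `O=C(Nc1ccc(Oc2ccc(-c3nccs3)cc2)cc1)Nc1cccc(C(F)(F)F)c1` and compound 2 `O=C(Nc1ccc(Oc2ccc(-c3nccs3)cc2)cc1)Nc1ccc(F)c(C(F)(F)F)c1` share one core. In a functional assay on MDA-MB-231 cells (Homo sapiens) for inhibition, read by MTT assay and WST assay, with a stated time of 72 h, tested at 10 uM (a lower number here means less inhibition of growth, a higher number more inhibition of growth at the concentration tested), compound 1 gives 64.1%, and compound 2 gives 71.8%. The change between them is fluoro in place of hydrogen on an aromatic carbon, and it produced a number 7.7 percentage points higher from compound 1 to compound 2 (within the scatter). Compound 3 `O=C(Nc1ccc(Oc2ccc(-c3ncc[nH]3)cc2)cc1)Nc1cccc(C(F)(F)F)c1` differs from compound 1 by 1H-imidazol-2-yl in place of 1,3-thiazol-2-yl on an aromatic carbon; in this assay compound 3 gives 28.1%, which means a number 36 percentage points lower from compound 1 to compound 3 (beyond the scatter). Compound 4 `O=C(Nc1ccc(Oc2ccc(-c3ncc[nH]3)cc2)cc1)Nc1ccc(F)c(C(F)(F)F)c1` has not yet been measured. It differs from compound 3 by fluoro in place of hydrogen on an aromatic carbon, the same change that turned compound 1 into compound 2. Because that earlier step was a number 7.7 percentage points higher from compound 1 to compound 2 (within the scatter), the step from compound 3 to compound 4 is expected to be similarly small, about a number 5.9 percentage points higher from compound 3 to compound 4 (within the scatter). In this assay compound 4 is therefore estimated at 34%, most likely between 20% and 50%.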

Compound 4, percent growth inhibition at one concentration: 26.6%
Compound 4: middle estimate off by 7.4 percentage points, on the high side, within the range that was stated.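

In this assay, the fluoro change gives a number 1.5 percentage points lower from compound 3 to compound 4 (within the scatter), and this step matches the earlier one on the core of compound 1: the same change on two cores in this assay, a number 7.7 percentage points higher (within the scatter) from compound 1 to compound 2 and a number 1.5 percentage points lower (within the scatter) from compound 3 to compound 4, 9.2 percentage points apart, within the scatter of two such steps. The change from 1,3-thiazol-2-yl to 1H-imidazol-2-yl also carries over, now with the fluoro present, giving a number 45.2 percentage points lower from compound 2 to compound 4 (beyond the scatter): the same change on two cores in this assay, a number 36 percentage points lower (beyond the scatter) from compound 1 to compound 3 and a number 45.2 percentage points lower (beyond the scatter) from compound 2 to compound 4, 9.2 percentage points apart, within the scatter of two such steps. This shows that each change behaved alike in the two settings tested, but two pairs cannot show that this holds on other cores, and neither fluoro step shows a real effect on growth inhibition.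

The compounds shown leave open how a chloro group, an amine or a carboxylic acid in place of the fluoro would behave on either core.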